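Amide variation on the shared core: difluoropiperidine replaces methoxymethylpiperidine

The source may report more compounds than this note shows. Statements on the series, on what has been measured and on what is new or still open speak of the compounds shown alone.

Three amides of the shared core have been measured. Compound 1 `CCN(CC)S(=O)(=O)c1ccc(S(=O)(=O)N2CCC[C@@H](C(=O)N3CCOCC3)C2)cc1` gives 350 nM in a functional assay on MIA PaCa-2 cells (Homo sapiens) for inhibition, read by MTT assay, with a stated time of 7 days; on this read-out lower numbers stand for stronger inhibition and higher numbers for weaker inhibition. Compound 2 `CCN(CC)S(=O)(=O)c1ccc(S(=O)(=O)N2CCC[C@@H](C(=O)N[C@H]3CCOC3)C2)cc1` gives 1670 nM; the change is a 4.8-fold higher number from compound 1 to compound 2 (0.68 log units; beyond the scatter). Compound 3 `CCN(CC)S(=O)(=O)c1ccc(S(=O)(=O)N2CCC[C@@H](C(=O)N3CCC(COC)CC3)C2)cc1` gives 250 nM, the lowest of the three numbers, but with a 1.4-fold lower number from compound 1 to compound 3 (0.15 log units; within the scatter) within the scatter, compound 3 and compound 1 are not separated; against compound 2 the gap is a 6.7-fold lower number from compound 2 to compound 3 (0.82 log units; beyond the scatter).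

Compound 4 `CCN(CC)S(=O)(=O)c1ccc(S(=O)(=O)N2CCC[C@@H](C(=O)N3CCC(F)(F)CC3)C2)cc1` carries the difference (4,4-difluoropiperidin-1-yl in place of 4-(methoxymethyl)piperidin-1-yl on a carbonyl carbon). The step that bears most directly is the cyclic tertiary amide exchange from compound 1 to compound 3, which stayed within the scatter; the larger steps involving compound 2 concern a secondary amide, which compound 4 does not have. Compound 4 is therefore expected to sit near compound 3, with a 1.6-fold higher number from compound 3 to compound 4 (0.20 log units; within the scatter) not beyond the scatter, allowing for the lost acceptor. The estimate for compound 4 is 400 nM, range 150 nM to 1100 nM.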

Compound 4, half-maximal inhibitory concentration: 16 nM
Beside the measured number, compound 4's estimate is 25-fold (1.40 log units) above it, outside the stated range (below it).
By their numbers in this assay, from the lowest: compound 4; then compounds 3 and 1 (each within the scatter of the next); then compound 2.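

The group on the carbonyl carbon is not the flat position that compounds 1 and 3 suggested: in this assay, 4,4-difluoropiperidin-1-yl gives a 16-fold lower number from compound 3 to compound 4 (1.19 log units; beyond the scatter) and a 22-fold lower number from compound 1 to compound 4 (1.34 log units; beyond the scatter). Against the secondary amide, the same group gives a 100-fold lower number from compound 2 to compound 4 (2.02 log units; beyond the scatter), so compound 4 stands apart, beyond the scatter, from all three other amides. Nothing available accounts for the size of these steps.

The compounds shown leave open whether the drop in the number depends on the two fluorine atoms or on the piperidine ring without an ether oxygen. Unsubstituted piperidin-1-yl and 4,4-dimethylpiperidin-1-yl on the same carbonyl carbon would separate these two readings.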